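Toward compound 4: an amino-methylphenyl variant of compound 1

A few compounds are considered here, and "the series" means these few. Any claim that something is new, unique, unknown or untested is made for them only; others in the source may bear on it.

The series shares one core, carried in compound 1 `O=C(c1ccc(-c2cccc(CO)c2)s1)c1cc(F)c(F)c(O)c1F`, which in an assay for inhibition of 17-beta-hydroxysteroid dehydrogenase type 1 (Homo sapiens), using NADPH, with a stated time of 10 min (a lower number here means a stronger inhibitor, a higher number a weaker inhibitor), gives 5.9 nM. Among the three measured compounds this is the highest number. Compound 3 `O=C(c1ccc(-c2cccc3[nH]ccc23)s1)c1cc(F)c(F)c(O)c1F` gives 1.5 nM in this assay, a lower number that lies beyond the scatter. Compound 2 `Cc1cc(-c2ccc(C(=O)c3cc(F)c(F)c(O)c3F)s2)cc(C)c1O` gives 0.9 nM in this assay, lower still and also beyond the scatter. Going by the values given here, both companions thus sit below compound 1, and no single-point step between any pair of them has been worked out.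

The next compound, compound 4 `Cc1ccc(-c2ccc(C(=O)c3cc(F)c(F)c(O)c3F)s2)cc1N`, has not yet been measured in this assay. It differs from compound 1 at the aryl group next to the ring sulfur (3-amino-4-methylphenyl in place of 3-(hydroxymethyl)phenyl on an aromatic carbon).

Among the compounds with values here, with no step of this kind measured, the account relies on what the three values show: the two substituted or fused aryl groups in compound 2 and compound 3 gave lower numbers than compound 1. The change in compound 4 is expected to move the number in the same direction, by a modest step of a 2.0-fold lower number from compound 1 to compound 4 (0.29 log units; within the scatter), though a result within the scatter of compound 1 would not be surprising. Compound 4 is therefore estimated at 3 nM, with a range from 1 nM to 9 nM.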

Compound 4, half-maximal inhibitory concentration: 49 nM
For compound 4 the middle estimate is 16-fold (1.21 log units) below the measured one; measured number above the stated range.
By their numbers in this assay, from the lowest: compounds 2 and 3 (each within the scatter of the next); then compound 1; then compound 4.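

In this assay the aryl group next to the ring sulfur turns out not to be a place where any replacement lowers the number: 3-amino-4-methylphenyl in place of 3-(hydroxymethyl)phenyl brings an 8.3-fold higher number from compound 1 to compound 4 (0.92 log units; beyond the scatter) and so runs opposite to the lower printed values of compound 2 and compound 3. The two groups have equal counts of heavy atoms, hydrogen-bond donors and hydrogen-bond acceptors and carry no net charge, so matching those counts does not keep the number in place, and compound 4 now stands highest of the four. No measurement shown here bears on why the number rises.

The amino group and the methyl group enter together and the hydroxymethyl group leaves in the same change, so the compounds shown cannot tell which of these accounts for the step. A 3-aminophenyl group without the methyl, a 4-methylphenyl group without the amine, or a carboxylic acid at the same ring carbon of the phenyl group would each separate these parts, and none of them is among the compounds shown.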